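Swapping cyclohexyl for benzyl on a bis-benzimidazole core

This account rests on a few compounds, and the source may have more. Where it says the series, first, only, none or still open, it means among the compounds named here.

Compound 1 `O=Cc1ccc(-c2cn3ccnc3c(-c3ccc4ncn(C5CCCCC5)c4c3)n2)cc1` and compound 2 `O=Cc1ccc(-c2cn3ccnc3c(-c3ccc4ncn(Cc5ccccc5)c4c3)n2)cc1` share a core bearing an aldehyde-substituted phenyl ring. In a functional assay on EKVX cells (Homo sapiens) for inhibition, read by sulforhodamine B assay, with a stated time of 48 h, tested at 10 uM (on this read-out higher numbers stand for more inhibition at the one concentration tested (going by the name of the read-out) and lower numbers for less inhibition), compound 1 gives 20.9%, and compound 2 gives 20.9%. The change between them is benzyl in place of cyclohexyl on an aromatic nitrogen, and it produced no change at the digits printed from compound 1 to compound 2 (within the scatter).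

Compound 3 `c1cn2cc(-c3ccc4c(c3)ncn4C3CCCCC3)nc(-c3ccc4ncn(C5CCCCC5)c4c3)c2n1` carries two cyclohexyl-bearing ring systems instead; in this assay compound 3 gives 60.2%, the highest of the three numbers, its nearest neighbour being compound 1. The difference between the core of compound 3 and that of compound 1 is not broken down here.

Compound 4 `c1ccc(Cn2cnc3ccc(-c4nc(-c5ccc6c(c5)ncn6C5CCCCC5)cn5ccnc45)cc32)cc1` differs from compound 3 by benzyl in place of cyclohexyl on an aromatic nitrogen, the same kind of change as benzyl in place of cyclohexyl on an aromatic nitrogen. Since that earlier change gave no change at the digits printed from compound 1 to compound 2 (within the scatter), the step is expected to be a number 2.2 percentage points lower from compound 3 to compound 4 (within the scatter). Compound 4 is therefore estimated at 58%, between 42% and 72%.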

Compound 4, a percentage reported as inhibition, at one concentration (the size of the read-out at that concentration, not a potency): -12.3%
Estimate against measurement, compound 4: 70.3 percentage points above; measured number below the stated range.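

The same swap does not behave alike on the two cores in this assay: the same change on two cores in this assay, no change at the digits printed (within the scatter) from compound 1 to compound 2 and a number 72.5 percentage points lower (beyond the scatter) from compound 3 to compound 4, 72.5 percentage points apart, beyond the scatter of two such steps

The second step, a number 72.5 percentage points lower from compound 3 to compound 4 (beyond the scatter), shows that a result seen on one core could not be carried over to the other in this series. It does not show why the two cores respond so differently, and two pairs give no rule for predicting this change on any further core.

The compounds shown leave open how other groups on that aromatic nitrogen would behave on each core, such as a plain methyl, a longer chain like phenethyl, or a chain ending in an amine.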